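Aryl change on the triazole of compound 1

The source may hold more compounds than are shown below. What is called first, only, known or untested is meant among the compounds shown, and "the series" means these compounds.

Measured in a functional assay on HeLa cells (Homo sapiens) for antiproliferative activity, read by MTT assay, with a stated time of 72 h; on this read-out lower numbers stand for stronger inhibition and higher numbers for weaker inhibition:
compound 1 `O=C1O[C@H]([C@@H](O)Cn2cc(-c3ccc(Br)cc3)nn2)C(OCc2ccccc2)=C1OCc1ccccc1`: 3910 nM
compound 2 `O=C1O[C@H]([C@@H](O)Cn2cc(-c3cc(C(F)(F)F)cc(C(F)(F)F)c3)nn2)C(OCc2ccccc2)=C1OCc1ccccc1`: 35500 nM
compound 3 `O=C1O/C(=C\Cn2cc(-c3cc(F)cc(F)c3)nn2)C(OCc2ccccc2)=C1OCc1ccccc1`: 17700 nM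

Compound 1 gives the lowest number of the three; compound 3 and compound 2 both sit beyond the scatter above it, compound 2 the further. No pair among these differs in one place, so no single-point step is available. Compound 4 `COc1ccccc1-c1cn(C[C@H](O)[C@H]2OC(=O)C(OCc3ccccc3)=C2OCc2ccccc2)nn1` differs from compound 1 by 2-methoxyphenyl in place of 4-bromophenyl on an aromatic carbon. Going by the values given here, nothing among the measured compounds tests this change, so its direction is open; in this assay the expected step is a 2.0-fold higher number from compound 1 to compound 4 (0.31 log units; beyond the scatter), modest and toward weaker inhibition, at most a little beyond the scatter. Compound 4 is estimated at 8000 nM in this assay, with a range from 2500 nM to 25000 nM.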

Compound 4, half-maximal inhibitory concentration: > 100000 nM
Compound 4: no number, only a limit; the forecaster's own chance of this, stated with the estimate: 10%; middle value at least 12-fold (1.09 log units) away from the limit.
By their numbers in this assay, from the lowest: compound 1; then compounds 3 and 2 (each within the scatter of the next). At a limit, above all of these: compound 4.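

In this assay compound 4 gives only a limit, > 100000 nM. Placing 2-methoxyphenyl instead of 4-bromophenyl on this aromatic carbon gives an at least 25-fold higher number from compound 1 to compound 4 (1.40 log units; beyond the scatter), the only single-place step shown, so the aryl group at this position can strongly shift the read-out. The size of this step is only a lower bound: the limit of > 100000 nM in this assay, at which 1 of the 4 values shown sits.

Going by these compounds alone, the single step cannot separate the loss of bromine from the gain of the methoxy group. On these data alone, how a plain phenyl or an aminophenyl at this carbon would compare with compound 1 remains open.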